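A few compounds are considered here, and "the series" means these few. Any claim that something is new, unique, unknown or untested is made for them only; others in the source may bear on it.

Compounds measured so far in an ADME assay on HepG2 cells (Homo sapiens) for cytotoxicity, read by MTT assay, with a stated time of 48 h; on this read-out lower numbers stand for higher toxicity in this test and higher numbers for lower toxicity in this test:

compound 1 `CC(=O)OC[C@H]1O[C@H](OC[C@@H](Cn2cc(CN(c3nc(-c4ccc(F)cc4)no3)C3CCCCC3)nn2)OC(C)=O)C=C[C@@H]1OC(C)=O`: 28.8 ug/mL
compound 2 `CC(=O)OC[C@H]1O[C@H](OC[C@@H](Cn2cc(CN(c3nc(-c4ccc(C)cc4)no3)C3CCCCC3)nn2)OC(C)=O)C=C[C@@H]1OC(C)=O`: 36.8 ug/mL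
compound 3 `CC(=O)OC[C@H]1O[C@H](OC[C@@H](Cn2cc(CN(c3nc(-c4ccccc4)no3)C3CCCCC3)nn2)OC(C)=O)C=C[C@@H]1OC(C)=O`: 19.9 ug/mL

Compound 3 lies within the scatter of both others, as the steps of a 1.4-fold lower number from compound 1 to compound 3 (0.16 log units; within the scatter) and a 1.8-fold lower number from compound 2 to compound 3 (0.27 log units; within the scatter) show. The unmeasured compound 4 `CC(=O)OC[C@H]1O[C@H](OC[C@@H](Cn2cc(CN(c3nc(-c4ccc(C(F)(F)F)cc4)no3)C3CCCCC3)nn2)OC(C)=O)C=C[C@@H]1OC(C)=O` differs from compound 3 by trifluoromethyl in place of hydrogen on an aromatic carbon. Going by the values given here, the two steps that bear on this place on the ring, a 1.4-fold lower number from compound 1 to compound 3 (0.16 log units; within the scatter) and a 1.8-fold lower number from compound 2 to compound 3 (0.27 log units; within the scatter), both stayed within the scatter, so exchanging one small group for another here has not moved this assay so far. Compound 4 is therefore expected to show no step beyond the scatter, a 1.3-fold higher number from compound 3 to compound 4 (0.10 log units; within the scatter). Compound 4 is estimated at 25 ug/mL, with a range from 12 ug/mL to 50 ug/mL.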

Compound 4, half-maximal cytotoxic concentration: 81.4 ug/mL
Estimate against measurement, compound 4: 3.3-fold (0.51 log units) below, outside the stated range (above it).
By their numbers in this assay, from the lowest: compounds 3, 1 and 2 (each within the scatter of the next); then compound 4.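

Going by these compounds alone, at this place on the aromatic ring, trifluoromethyl is the first group to produce a step beyond the scatter in this assay, with a 4.1-fold higher number from compound 3 to compound 4 (0.61 log units; beyond the scatter) against hydrogen. It also stands apart from the other two groups, with a 2.2-fold higher number from compound 2 to compound 4 (0.34 log units; beyond the scatter) against methyl and a 2.8-fold higher number from compound 1 to compound 4 (0.45 log units; beyond the scatter) against fluoro, so this position can respond even though hydrogen, fluoro and methyl stay within the scatter of one another. No measurement at hand offers an explanation for this step. The compounds shown leave open whether a nitrile, a methoxy group or a chlorine atom at this place would give a similar step, or whether it is confined to trifluoromethyl.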